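The compounds below may be only part of what the source reports. "The series", "measured", "known", "first", "only" and "open" are said of these compounds alone.

Measured compounds:
compound 1 `COc1ccc2cc(C(C)c3nnc4n3N=C(c3ccc([N+](=O)[O-])cc3)CS4)ccc2c1`; in a functional assay on Huh-7 cells (Homo sapiens) for inhibition, read by sulforhodamine B assay, with a stated time of 72 h (a lower number here means a stronger inhibitor, a higher number a weaker inhibitor), compound 1 gives 14700 nM.
compound 2 `CC(c1ccc(-c2ccccc2)c(F)c1)c1nnc2n1N=C(c1ccc(OC(F)(F)F)cc1)CS2`; compound 2 gives 8400 nM.
compound 3 `CC(c1ccc(-c2ccccc2)c(F)c1)c1nnc2n1N=C(c1ccc(Cl)cc1Cl)CS2`; compound 3 gives 3700 nM.

Compound 3 has the lowest number of the three, with compound 2 nearest and compound 1 furthest. Compound 4 `CC(c1ccc(-c2ccccc2)c(F)c1)c1nnc2n1N=C(c1ccccc1)CS2` differs from compound 3 by phenyl in place of 2,4-dichlorophenyl on a carbon with a double bond to nitrogen. Within the data shown here, the one measured step at this place is a 2.3-fold lower number from compound 2 to compound 3 (0.36 log units; beyond the scatter), which shows that the group on this carbon can move the number beyond the scatter. Among the measured compounds shown here, no measured step leads to a plain phenyl here, so the size is uncertain. A modest rise in this assay is expected, about a 2.2-fold higher number from compound 3 to compound 4 (0.33 log units; beyond the scatter). Compound 4 is estimated at 8000 nM, with a likely range from 3500 nM to 18000 nM.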

Compound 4, half-maximal inhibitory concentration: 6700 nM
Estimate against measurement, compound 4: 1.2-fold (0.08 log units) above; the range from low to high includes it.
By their numbers in this assay, from the lowest: compounds 3, 4, 2 and 1 (each within the scatter of the next, the first and the last beyond it).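

With phenyl in place of 2,4-dichlorophenyl in this assay, the result is a 1.8-fold higher number from compound 3 to compound 4 (0.26 log units; within the scatter), and with hydrogen in place of trifluoromethoxy on the aromatic carbon, it is a 1.3-fold lower number from compound 2 to compound 4 (0.10 log units; within the scatter). Plain phenyl on this carbon therefore cannot be told apart from either substituted ring, even though those two rings differ beyond the scatter. Nothing available explains these steps. As far as these compounds go, whether an amine or a carboxylic acid on this phenyl would move the number beyond the scatter remains open. So does whether a single chlorine would match the 2,4-dichlorophenyl group.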